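The source may hold more compounds than are shown below. What is called first, only, known or untested is meant among the compounds shown, and "the series" means these compounds.

Compound 1 (`CC(C)C(CC1C(=O)NC(=O)N1C)c1ccc(-c2ccc3cccc(F)c3c2)[nH]c1=O`) sits at the low end of the results so far. Among the measured compounds shown here, in an ADME assay on microsomes from liver (Homo sapiens) for metabolic stability (a higher number here means that the compound lasts longer, a lower number that the compound disappears faster), compound 1 gives 0.153 h as the lower of the only two actual numbers. Compound 2 (`O=C1NC(=O)/C(=C/C(c2ccc(-c3ccc4cccc(F)c4c3)[nH]c2=O)C2CCCCC2)O1`) gives 1.09 h in this assay as a clearly longer half-life, with a gap well beyond the usual scatter. For compound 3 (`CCC(/C=C1\OC(=O)NC1=O)(CC)c1ccc(-c2ccc3cc(F)cc(F)c3c2)[nH]c1=O`) the result is > 3 h in this assay and this is a limit of the assay, not a number.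

Compound 4 (`CC(C)C(/C=C1\SC(=O)NC1=O)c1ccc(-c2ccc3cccc(F)c3c2)[nH]c1=O`) has not yet been measured. The change from compound 1 (a group of 8 heavy atoms (4 carbon, 1 nitrogen, 2 oxygen, 1 sulfur; one five-membered non-aromatic ring with 2 hetero atoms) in place of a group of 9 heavy atoms (5 carbon, 2 nitrogen, 2 oxygen; one five-membered non-aromatic ring with 2 hetero atoms), on a saturated chain carbon bound to an aromatic carbon and a saturated chain carbon) removes the (3-methyl-2,5-dioxoimidazolidin-4-yl)methyl group and puts a different five-membered non-aromatic ring group, this one containing sulfur, on a saturated chain carbon bound to an aromatic carbon and a saturated chain carbon. For the measured compounds named here, no measured pair shows this change alone, so the expectation is a rough one. The entering group resembles the matching part of compound 2, which gives 1.09 h in this assay, more than it resembles the group that leaves. A rise in half-life beyond the scatter is therefore expected, and the estimated change is a 5.2-fold higher number from compound 1 to compound 4 (0.72 log units; beyond the scatter) in this assay overall. For compound 4 the estimated half-life is 0.8 h, with an expected range of 0.3 h to 2.5 h for repeat measurements.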

Compound 4, half-life: > 3 h
Compound 4: no number, only a limit; the forecaster's own chance of this, stated with the estimate: 10%; middle value at least 3.7-fold (0.57 log units) from the limit.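

Among the compounds shown here, the only step so far between compounds that differ in one place shows that this position has a strong hold on half-life: on the saturated chain carbon bound to an aromatic carbon and a saturated chain carbon, putting the sulfur-containing five-membered ring group in place of the (3-methyl-2,5-dioxoimidazolidin-4-yl)methyl group gives an at least 19-fold higher number from compound 1 to compound 4 (1.29 log units; beyond the scatter) in this assay, with the rest of the molecule unchanged. For compound 4 the result of > 3 h is a limit of the assay and not a number. The size of this step is therefore only a lower bound, and any further gain from changes at this position would not appear as a number: the limit of > 3 h in this assay, at which 2 of the 4 values shown sit.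

The swap changes several things at once, including the ring atoms, the methyl group on the ring, and the double bond in the link to the chain, so this one pair cannot say which of them matters for the rise in half-life. From the compounds shown here alone, it also remains open how a much simpler group in the same place, such as a carboxylic acid or an amine, would behave in this assay.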